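Methyl in Place of Methoxy: Expectation for Compound 4

The source may hold more compounds than are shown below. What is called first, only, known or untested is meant among the compounds shown, and "the series" means these compounds.

The three compounds measured so far in an assay on Sf9 cells for inhibition of protein deacetylase HDAC6 (Homo sapiens), read by fluorescence, with stated times of 90 min and 30 min (a lower number here means a stronger inhibitor, a higher number a weaker inhibitor), are:
compound 1 `Cc1cc(C)cc(C(=O)N(CCC(=O)NCc2ccccc2)Cc2ccc(C(=O)NO)cc2)c1`: 20.5 nM
compound 2 `COc1cc(OC)cc(C(=O)N(CCC(=O)NCc2ccccc2)Cc2ccc(C(=O)NO)cc2)c1`: 26 nM
compound 3 `COc1ccc(C(=O)N(CCC(=O)NCc2ccccc2)Cc2ccc(C(=O)NO)cc2)cc1`: 25.3 nM

Compound 3 sits second highest of these three numbers, but all three lie close together. The step of a 1.0-fold lower number from compound 2 to compound 3 (0.01 log units; within the scatter) is essentially nil, and the step of a 1.2-fold higher number from compound 1 to compound 3 (0.09 log units; within the scatter) is also within the scatter, as is a 1.3-fold higher number from compound 1 to compound 2 (0.10 log units; within the scatter). Across these three compounds, then, the exchanges of the aryl group bonded to the carbonyl carbon traced by these steps, which trade methyl for methoxy substituents or vary their placement, have produced no change beyond the scatter.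

Compound 4 `Cc1ccc(C(=O)N(CCC(=O)NCc2ccccc2)Cc2ccc(C(=O)NO)cc2)cc1` differs from compound 3 in one place: methyl in place of methoxy on an aromatic carbon. Among the measured compounds shown here, the steps that bear on this are those between compound 1 and compound 3 and between compound 1 and compound 2, both of which trade methyl for methoxy on the same aryl group and both of which were within the scatter. On that basis no step beyond the scatter is expected in this assay in either direction, and the estimated step is a 1.1-fold lower number from compound 3 to compound 4 (0.04 log units; within the scatter). Compound 4 is therefore expected to give about 23 nM in this assay, most likely between 11 nM and 50 nM.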

Compound 4, half-maximal inhibitory concentration: 16.7 nM
Beside the measured number, compound 4's estimate is 1.4-fold (0.14 log units) above it; measured number inside the range.
By their numbers in this assay, from the lowest: compounds 4, 1, 3 and 2 (each within the scatter of the next).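

Among the compounds shown here, compound 3 and compound 4 isolate methyl in place of methoxy at a single place, on an aromatic carbon para to a large group, whereas the earlier steps changed the number or placement of the substituents along with their kind; in this assay, this clean exchange gives a 1.5-fold lower number from compound 3 to compound 4 (0.18 log units; within the scatter) and stays inside the scatter. Replacing the whole aryl group with 4-methylphenyl gives a 1.6-fold lower number from compound 2 to compound 4 (0.19 log units; within the scatter) when 3,5-dimethoxyphenyl leaves and a 1.2-fold lower number from compound 1 to compound 4 (0.09 log units; within the scatter) when 3,5-dimethylphenyl leaves, so among these four compounds neither the methyl-for-methoxy exchange nor these changes of substitution on the aryl group moves the number beyond the scatter. Nothing among the data shown accounts for the sizes of these steps.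

On these data alone, the aryl groups here carry only methyl or methoxy, so it remains open whether an amine, a carboxylic acid or a longer chain such as butyl at this place would give a step beyond the scatter. As far as these compounds go, the rest of the shared core is the same in all four compounds, and what a change there would do also remains open.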